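Compound 4: phenoxy in place of 4-chlorophenoxy

A few compounds are considered here, and "the series" means these few. Any claim that something is new, unique, unknown or untested is made for them only; others in the source may bear on it.

Three compounds share one core and differ only on the benzyl group: compound 1 `Cc1ccc(CO/N=C/c2c(C)nn(C)c2Oc2ccc(Cl)cc2)cc1`, compound 2 `CCOC(=O)c1ccc(CO/N=C/c2c(C)nn(C)c2Oc2ccc(Cl)cc2)cc1` and compound 3 `Cc1nn(C)c(Oc2ccc(Cl)cc2)c1/C=N/OCc1ccc([N+](=O)[O-])cc1`. In a functional assay on A549 cells (Homo sapiens) for antiproliferative activity, tested at 1 uM (a higher number here means more inhibition at the concentration tested (going by the name of the read-out), a lower number less inhibition), compound 1 gives 50%, compound 2 gives 48.2% and compound 3 gives 39.6%. Compound 3 stands lowest of the three, with a number 10.4 percentage points lower from compound 1 to compound 3 (beyond the scatter) and a number 8.6 percentage points lower from compound 2 to compound 3 (within the scatter); the remaining step is a number 1.8 percentage points lower from compound 1 to compound 2 (within the scatter). Compound 4 `Cc1nn(C)c(Oc2ccccc2)c1/C=N/OCc1ccc([N+](=O)[O-])cc1` keeps the nitro group of compound 3 and alters the other ring instead: hydrogen in place of chloro on an aromatic carbon. Within the data shown here, none of the measured steps touches this ring; they offer no guide to the size of this change. With nothing pointing to a shift, no step beyond the scatter is expected, a number 3.6 percentage points lower from compound 3 to compound 4 (within the scatter). Compound 4 is therefore estimated at 36% in this assay, ranging from 16% to 56%.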

Compound 4, a percentage reported as inhibition, at one concentration (the size of the read-out at that concentration, not a potency): 39.4%
Compound 4: middle estimate off by 3.4 percentage points, on the low side; measured number inside the range.
By their numbers in this assay, from the lowest: compounds 4, 3, 2 and 1 (each within the scatter of the next, the first and the last beyond it).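

This is the first change shown away from the benzyl group: in this assay, hydrogen in place of chloro on the phenoxy ring gives a number 0.2 percentage points lower from compound 3 to compound 4 (within the scatter) and so leaves the read-out within the scatter. With the nitro group in place, the chlorine is therefore not needed to hold the inhibition at this concentration. No available evidence bears on this result.

From the compounds shown here alone, whether the same holds alongside the methyl of compound 1 or the ethoxycarbonyl of compound 2 remains open. Going by these compounds, the effect of a methoxy group, an amine or a carboxylic acid at this ring position also remains open.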